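A few compounds are considered here, and "the series" means these few. Any claim that something is new, unique, unknown or untested is made for them only; others in the source may bear on it.

Measured so far:
Compound 1, `O=C(CN(c1nc(Cl)nc2[nH]cnc12)C1CC1)N[C@@H](CO)C(=O)OCc1ccccc1`, in a functional assay on the whole organism (Tail, strain ICR) with Mus musculus as the target, in the tail flick test, with a stated time of 60 min, at a dose of 25 umol/kg by the oral route (on this read-out lower numbers stand for a weaker effect and higher numbers for a stronger effect at the one dose given), gives 34.2%.
Compound 2, `CC[C@H](C)[C@H](NC(=O)CN(c1nc(Cl)nc2[nH]cnc12)C1CC1)C(=O)O`, in this assay gives 36%.

Compound 2 holds the higher of the two numbers, but the nearest one, that of compound 1, lies within the scatter of it, so the two cannot be told apart.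

Compound 3, `O=C(CN(c1nc(Cl)nc2[nH]cnc12)C1CC1)N[C@@H](CO)C(=O)O`, has not yet been measured in this assay. It differs from compound 2 in one place: hydroxymethyl in place of sec-butyl on a saturated chain carbon bound to an amide-type nitrogen and a carbonyl carbon. Among the compounds with values here, no step between two measured compounds is available to gauge a change of this kind, so the expectation rests on the two numbers alone, which sit close together. For compound 3 the expected step of a number 3 percentage points lower from compound 2 to compound 3 (within the scatter) is none beyond the scatter. Compound 3 is therefore expected to give about 33%, with a range from 18% to 48%.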

Compound 3, a percentage reported as activity, at one dose (the size of the read-out at that dose, not a potency): 39.8%
Estimate against measurement, compound 3: 6.8 percentage points below; low and high end bracket the measured number.
By their numbers in this assay, from the lowest: compounds 1, 2 and 3 (each within the scatter of the next).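

Placing hydroxymethyl where sec-butyl stood, on a saturated chain carbon bound to an amide-type nitrogen and a carbonyl carbon, gives a number 3.8 percentage points higher from compound 2 to compound 3 (within the scatter) in this assay, so a smaller side chain carrying an oxygen and a branched all-carbon one cannot be told apart at this place. Hydrogen in place of benzyl on an oxygen next to a carbonyl group gives a number 5.6 percentage points higher from compound 1 to compound 3 (within the scatter), so removing the benzyl group also leaves no difference that can be read. Nothing measured here explains either step.

On these data alone, whether an amine or a phenyl ring at the place of hydroxymethyl would shift the number beyond the scatter remains open. These numbers also come from a single dose, so they show only the size of the effect at that dose.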